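This account rests on a few compounds, and the source may have more. Where it says the series, first, only, none or still open, it means among the compounds named here.

Measured so far:
compound 1 `Cc1cc(F)ccc1[C@H]1C[C@H](N2CCC2)CCN1C(=O)N(C)[C@H](C)c1cc(C(F)(F)F)cc(C(F)(F)F)c1` with 0.646 nM
compound 2 `Cc1cc(F)ccc1[C@H]1C[C@@H](N2CCCC2)CCN1C(=O)N(C)[C@H](C)c1cc(C(F)(F)F)cc(C(F)(F)F)c1` with 0.141 nM

These two compounds were tested in an assay on CHO cells for displacement of a labelled ligand from Substance-P receptor (Homo sapiens), read by scintillation counting; on this read-out lower numbers stand for stronger inhibition and higher numbers for weaker inhibition. Within the data shown here, compound 2 gives the lowest of the two numbers; the only neighbour is compound 1, whose number is higher by a gap that lies beyond the usual scatter, so compound 2 is the stronger binder of the pair.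

The next compound, compound 3 `Cc1cc(F)ccc1[C@H]1C[C@H](N2CCCC2)CCN1C(=O)N(C)[C@H](C)c1cc(C(F)(F)F)cc(C(F)(F)F)c1`, keeps every atom and bond of compound 2. What changes is only the configuration at one centre: the two compounds have the same atoms and bonds and differ only in configuration as drawn: 1 of 3 stereo elements differ; a stereocentre at a saturated ring carbon is drawn S in compound 2 and R in compound 3. Among the measured compounds shown here, no measured pair here shows what such an inversion does at this position, so the size of the step cannot be read off directly. The expectation is that the inverted centre fits less well and the number rises, likely beyond the scatter rather than staying within it, with an 11-fold higher number from compound 2 to compound 3 (1.03 log units; beyond the scatter) as the estimated step. On that basis compound 3 is expected to give 1.5 nM, within a range from 0.4 nM to 6 nM.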

Compound 3, inhibition constant: 0.2 nM
For compound 3 the middle estimate is 7.5-fold (0.88 log units) above the measured one, and the stated range ends above it.
By their numbers in this assay, from the lowest: compounds 2 and 3 (each within the scatter of the next); then compound 1.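

In this assay, inverting the saturated ring carbon that carries the pyrrolidin-1-yl group gives a 1.4-fold higher number from compound 2 to compound 3 (0.15 log units; within the scatter), so this read-out cannot separate the two drawn configurations at this centre, and nothing else in the structures competes with that result: the fact that compounds 2 and 3 differ only in the configuration as drawn

The group on that carbon does register, since pyrrolidin-1-yl in place of azetidin-1-yl gives a 3.2-fold lower number from compound 1 to compound 3 (0.51 log units; beyond the scatter), a modest step that lies beyond the scatter. Among these three compounds, then, changing the amine ring at this position shows up in the numbers, while inverting the centre in the pyrrolidin-1-yl series does not.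

Whether the same tolerance of inversion holds with azetidin-1-yl on this carbon remains open, as the compounds shown offer only one configuration of that group. Also open, as far as these compounds go, is how a larger ring such as piperidin-1-yl, a ring with a second heteroatom such as morpholin-4-yl, or an open-chain amine such as dimethylamino would behave at this position, in either configuration.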